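A few compounds are considered here, and "the series" means these few. Any claim that something is new, unique, unknown or untested is made for them only; others in the source may bear on it.

Compound 1 `COc1cc(-c2cc(/C=C/C(=O)c3ccc(N)cc3)[nH]n2)cc(OC)c1OC` and compound 2 `COc1ccc(-c2cc(/C=C/C(=O)c3ccc(N)cc3)[nH]n2)cc1OC` share one core, while compound 3 `COc1cc(C(=O)/C=C/c2cc(-c3cc(OC)c(OC)c(OC)c3)n[nH]2)cc(OC)c1OC` is built on a different one; the difference between the two cores is not broken down here. In a functional assay on IGROV-1 cells (Homo sapiens) for cytotoxicity, read by sulforhodamine B assay, with a stated time of 48 h, tested at 100 uM (on this read-out higher numbers stand for a weaker effect at the one concentration tested and lower numbers for a stronger effect), compound 1 gives -49% and compound 2 gives -62%, so that a number 13 percentage points lower from compound 1 to compound 2 (beyond the scatter) for (hydrogen in place of methoxy on an aromatic carbon). Compound 3 gives -97%, the lowest number of the three. Compound 4 `COc1ccc(-c2cc(/C=C/C(=O)c3cc(OC)c(OC)c(OC)c3)[nH]n2)cc1OC` carries the same change on the core of compound 3, namely (hydrogen in place of methoxy on an aromatic carbon). On compound 1 this change made a modest step; on compound 3 the starting point is already far down, so in this assay compound 4 is expected to move by about a number 3 percentage points higher from compound 3 to compound 4 (within the scatter), resting on the step from compound 1 to compound 2 and on the low number of compound 3. Compound 4 is therefore estimated at -94%, between -100% and -78%.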

Compound 4, a percentage reported as activity, at one concentration (the size of the read-out at that concentration, not a potency): -72%
The estimate for compound 4 lay 22 percentage points below the measured number, outside the stated range (above it).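

In this assay, replacing methoxy with hydrogen gave a number 25 percentage points higher from compound 3 to compound 4 (beyond the scatter), and this step does not match the earlier one in size or direction: the same change on two cores in this assay, a number 13 percentage points lower (beyond the scatter) from compound 1 to compound 2 and a number 25 percentage points higher (beyond the scatter) from compound 3 to compound 4, 38 percentage points apart, beyond the scatter of two such steps. The step seen on one core therefore did not carry over to the other in this series, since the number fell on the core of compound 1 and rose on the core of compound 3. Among these compounds, with only one pair on each core, this does not show why the two steps differ or how the change would behave on any further core.

The compounds shown leave open what a hydroxyl or a fluorine in that place would do on either core. They also leave open whether the two steps would keep their direction at other concentrations.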